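Replacing cyano with isopropyl on the aromatic ring

The source may hold more compounds than are shown below. What is called first, only, known or untested is meant among the compounds shown, and "the series" means these compounds.

Compound 1, `CCC(COc1cccc(Cl)c1)OC(=O)NCc1ccccc1`: > 100000 nM
Compound 2, `CCC(COc1cccc(C#N)c1)OC(=O)NCc1ccccc1`: > 100000 nM

Both numbers come from an assay for inhibition of zeta-carotene desaturase, chloroplastic/chromoplastic (Capsicum annuum), using a Dixon plot, with a stated time of 8 h; a higher number here means a weaker inhibitor, a lower number a stronger inhibitor. For compound 1 the value > 100000 nM is a limit of the assay and not a measured number. For compound 2 the value > 100000 nM is likewise a limit. The step that the two limits leave unreadable from compound 1 to compound 2 therefore has no readable size, since both ends sit at the limit of > 100000 nM in this assay, at which 2 of the 2 values shown sit. Compound 2 thus stands at the limit of this assay, with nothing to set it apart from compound 1.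

Compound 3, `CCC(COc1cccc(C(C)C)c1)OC(=O)NCc1ccccc1`, has not yet been measured. It differs from compound 2 by isopropyl in place of cyano on an aromatic carbon. Among the compounds with values here, the only measured step, from compound 1 to compound 2, cannot be read, so it offers no guide to either the direction or the size of the coming change. With no readable step to build on, the step that the limit leaves unreadable from compound 2 to compound 3 is expected to be negligible. Compound 3 is expected to give about 150000 nM in this assay, within 30000 nM to 1000000 nM, and is most likely to be reported once more as a limit rather than a number.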

Compound 3, half-maximal inhibitory concentration: > 100000 nM
Compound 3 gave a limit, no number; the forecaster's own chance of this, stated with the estimate: 85%; the middle value is on the limit's open side.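

In this assay compound 3 gives > 100000 nM, a limit of the assay and not a number. No step among compound 1, compound 2 and compound 3 can be read, since all three sit at the same limit: the limit of > 100000 nM in this assay, at which 3 of the 3 values shown sit.

The compounds shown leave open how strongly each one inhibits, and whether chloro, cyano or isopropyl on the aromatic ring makes any difference.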